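Ring substituent swap on the pyridin-4-yl of the shared core

The source may hold more compounds than are shown below. What is called first, only, known or untested is meant among the compounds shown, and "the series" means these compounds.

Compound 3 `COCc1cc(-c2noc([C@H](C)NC(=O)c3cc(C(F)(F)F)nn3C)n2)ccn1` gives 322 nM in an assay on T-REx-293 cells for inhibition of potassium channel subfamily T member 1 (Homo sapiens), read by patch clamp (a higher number here means a weaker inhibitor, a lower number a stronger inhibitor), the lowest of the two numbers shown; compound 2 `COc1cc(-c2noc([C@H](C)NC(=O)c3cc(C(F)(F)F)nn3C)n2)cc(C)n1` gives 505 nM, and the step of a 1.6-fold lower number from compound 2 to compound 3 (0.20 log units; within the scatter) is within the scatter. Compound 1 `C[C@H](NC(=O)c1cc(C(F)(F)F)nn1C)c1nc(-c2ccccn2)no1` gives only a limit, > 30000 nM (the limit of > 30000 nM in this assay, at which 1 of the 3 values shown sits). The steps of an at least 59-fold lower number from compound 1 to compound 2 (1.77 log units; beyond the scatter) and an at least 93-fold lower number from compound 1 to compound 3 (1.96 log units; beyond the scatter) were large, but both replace pyridin-2-yl by a substituted pyridin-4-yl. Compound 4 `C[C@H](NC(=O)c1cc(C(F)(F)F)nn1C)c1nc(-c2ccnc(C(F)(F)F)c2)no1` keeps the pyridin-4-yl and differs from compound 3 by trifluoromethyl in place of methoxymethyl on an aromatic carbon. Among the measured compounds shown here, only the step from compound 2 to compound 3 changes the same kind of position, and it was within the scatter; no measured step tests trifluoromethyl. Expected step: a 1.6-fold higher number from compound 3 to compound 4 (0.19 log units; within the scatter), not beyond the scatter. For compound 4 the estimate is 500 nM, ranging from 150 nM to 2000 nM.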

Compound 4, half-maximal inhibitory concentration: 40 nM
For compound 4 the middle estimate is 13-fold (1.10 log units) above the measured one; the measured number lies below the stated range.
By their numbers in this assay, from the lowest: compound 4; then compounds 3 and 2 (each within the scatter of the next). At a limit, above all of these: compound 1.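

Of the substituted pyridin-4-yl groups shown, only 2-(trifluoromethyl)pyridin-4-yl separates beyond the scatter: an 8.1-fold lower number from compound 3 to compound 4 (0.91 log units; beyond the scatter), and a 13-fold lower number from compound 2 to compound 4 (1.10 log units; beyond the scatter), while compound 2 and compound 3 lie within the scatter of each other. The position next to the ring nitrogen therefore responds to the group it carries, which the earlier pair could not show. The step of an at least 750-fold lower number from compound 1 to compound 4 (2.87 log units; beyond the scatter) is only a bound, as compound 1 stands at a limit: the limit of > 30000 nM in this assay, at which 1 of the 4 values shown sits.

Going by these compounds, whether a chlorine, a nitrile or a pentafluoroethyl group at this carbon would match trifluoromethyl stays open. So does the effect of trifluoromethyl on the pyridin-2-yl of compound 1.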